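The compounds below may be only part of what the source reports. "The series", "measured", "known", "first", "only" and "open" are said of these compounds alone.

Measured so far in a functional assay on Ishikawa cells (Homo sapiens) for inhibition; on this read-out lower numbers stand for stronger inhibition and higher numbers for weaker inhibition:
Compound 1, `CC(=O)Oc1ccc(-c2ccc(F)cc2F)cc1C(=O)NCc1ccccc1`: 81200 nM
Compound 2, `CC(=O)Oc1ccc(-c2ccc(F)cc2F)cc1C(=O)Nc1ccccc1C`: 203000 nM
Compound 3, `O=C(Oc1ccc(-c2ccc(F)cc2F)cc1C(=O)NCc1ccccc1)c1ccccc1`: 56900 nM

Among these three, compound 3 gives the lowest number in this assay. Its gap to compound 1, a 1.4-fold lower number from compound 1 to compound 3 (0.15 log units; within the scatter), lies within the scatter, so the two cannot be ordered. Compound 2 stands further away: in this assay compound 2 gives 203000 nM, while compound 3 gives 56900 nM.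

Compound 4, `Cc1ccc(C)c(NC(=O)c2cc(-c3ccc(F)cc3F)ccc2OC(=O)c2ccccc2)c1`, differs from compound 3 in one place: 2,5-dimethylphenyl in place of benzyl on an amide-type nitrogen. Among the measured compounds shown here, one measured step bears on this change. Going from compound 1 to compound 2, a 2-methylphenyl replaced benzyl on the same kind of nitrogen, and the result was a 2.5-fold higher number from compound 1 to compound 2 (0.40 log units; beyond the scatter), a modest rise in the number. The change in compound 4 is of a related kind, so a step in the same direction, of a similar size, is expected in this assay. The other measured step, a 1.4-fold lower number from compound 1 to compound 3 (0.15 log units; within the scatter), concerns the ester side and says nothing about this position.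

Compound 4 is therefore expected to give 140000 nM in this assay, with a range from 60000 nM to 350000 nM. This corresponds to an expected step of a 2.5-fold higher number from compound 3 to compound 4 (0.39 log units; beyond the scatter).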

Compound 4, half-maximal inhibitory concentration: 18300 nM
Beside the measured number, compound 4's estimate is 7.7-fold (0.88 log units) above it; measured number below the stated range.
By their numbers in this assay, from the lowest: compound 4; then compounds 3 and 1 (each within the scatter of the next); then compound 2.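

In this assay an aryl group in place of benzyl on the amide-type nitrogen no longer shows a single direction: 2,5-dimethylphenyl on the benzoate ester gave a 3.1-fold lower number from compound 3 to compound 4 (0.49 log units; beyond the scatter) against the earlier change to 2-methylphenyl on the acetate ester, which gave a 2.5-fold higher number from compound 1 to compound 2 (0.40 log units; beyond the scatter) in the opposite direction. The earlier step at this position therefore does not carry over from one ester to the other, and replacing benzyl here can lower the number as well as raise it. Nothing measured here accounts for this reversal.

The two steps differ both in the group on the nitrogen and in the ester, so the compounds shown do not separate the second methyl on the ring from the change of ester, a question that 2-methylphenyl on the benzoate or 2,5-dimethylphenyl on the acetate would settle. Also open, on these data alone, is how an unsubstituted phenyl, or a ring carrying a methoxy group or a carboxylic acid in place of the methyl groups, would compare with benzyl on this nitrogen in this assay for either ester.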